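Amino for Chloro on the Shared Core: an Expected Step

The source may hold more compounds than are shown below. What is called first, only, known or untested is meant among the compounds shown, and "the series" means these compounds.

Measured so far:
compound 1 `Nc1nc(Cl)c2ncn(Cc3ccc(CCl)cc3)c2n1` gives > 100000 nM
compound 2 `ClCc1cccc(Cn2cnc3c(Cl)nc(Cl)nc32)c1` gives 6310 nM
compound 3 `ClCc1ccc(Cn2cnc3c(Cl)nc(Cl)nc32)cc1` gives 50100 nM

Of the compounds shown here, three have been tested in a functional assay on MDA-MB-435 cells (Homo sapiens) for cytotoxicity, read by sulforhodamine B assay, with a stated time of 48 h; a lower number here means that less compound is tolerated, a higher number that more compound is tolerated. Compound 2 shows the lowest of the two numbers, and compound 3 sits at a higher number, a gap that is beyond the scatter. For compound 1 the assay reports only a limit, namely (the limit of > 100000 nM in this assay, at which 1 of the 3 values shown sits), and no number.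

Compounds 2 and 3 are built from the same atoms joined differently; the difference between their two cores is not broken down here. Compound 1 differs from compound 3 by amino in place of chloro on an aromatic carbon, and that change produced an at least 1.9-fold higher number from compound 3 to compound 1 (0.30 log units; that floor lies within the scatter).

The unmeasured compound 4 `Nc1nc(Cl)c2ncn(Cc3cccc(CCl)c3)c2n1` differs from compound 2 by the same change, (amino in place of chloro on an aromatic carbon). Because compound 1 ended at the limit of > 100000 nM in this assay, at which 1 of the 3 values shown sits, the step from compound 3 to compound 1 may be larger than its floor, so from compound 2 to compound 4 a step of a 4.8-fold higher number from compound 2 to compound 4 (0.68 log units; beyond the scatter) is expected. Compound 4 is therefore estimated at 30000 nM in this assay, with a likely span from 10000 nM to 120000 nM.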

Compound 4, concentration lethal to 50% of the cells: 85100 nM
Compound 4: the middle estimate sits 2.8-fold (0.45 log units) below what was measured; measured number inside the range.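

In this assay, amino in place of chloro on an aromatic carbon gives a 13-fold higher number from compound 2 to compound 4 (1.13 log units; beyond the scatter), so on the core of compound 2 the change brings a large step, in the same direction as on the core of compound 3: the same change on two cores in this assay, an at least 1.9-fold higher number (0.30 log units; that floor lies within the scatter) from compound 3 to compound 1 and a 13-fold higher number (1.13 log units; beyond the scatter) from compound 2 to compound 4; the limit leaves it open whether they differ

Compound 1 is known only through a limit, > 100000 nM, and not through a number. The two cores therefore agree in direction, but the compounds do not show whether the change carries over with the same size or with a different one.

The compounds shown leave open whether another group on that aromatic carbon, such as methylamino or methoxy, would move the number in the same way. They also leave open whether the amino for chloro step would hold if a hydroxymethyl group stood in place of the chloromethyl group on the benzyl ring.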